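The source may hold more compounds than are shown below. What is called first, only, known or untested is meant among the compounds shown, and "the series" means these compounds.

Measured so far:
- compound 1, `Cc1ccc(F)cc1NC[C@@H]1[C@@H](c2ccc(S(N)(=O)=O)cc2)C1(C)C`: 0% in a functional assay on the whole organism with Mus musculus as the target, with stated times of 60 min and 30 min, at a dose of 3 mg/kg by the oral route; a higher number here means more inhibition at the dose given (going by the name of the read-out), a lower number less inhibition
- compound 2, `CC1(C)[C@@H](CNc2ccc(F)cc2OC(F)F)[C@@H]1c1ccc(S(N)(=O)=O)cc1`: 16%

Compound 1 stands lowest of the two numbers in this assay; the nearest is compound 2, whose number lies higher by a gap beyond the usual scatter. Compound 3, `Cc1cc(F)c(F)cc1NC[C@@H]1[C@@H](c2ccc(S(N)(=O)=O)cc2)C1(C)C`, is not yet measured. It differs from compound 1 by fluoro in place of hydrogen on an aromatic carbon. No step between measured compounds that differ in one place is known, so the size of this step in this assay cannot be read from shown data. A single added fluoro is expected to give at most a small step, likely within the scatter. The expected step is a number 8 percentage points higher from compound 1 to compound 3 (within the scatter). Compound 3 is estimated at 8%, ranging from 0% to 25%.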

Compound 3, a percentage reported as inhibition, in the whole organism at one dose (the size of the read-out at that dose, not a potency): 31%
Compound 3: the middle estimate sits 23 percentage points below what was measured; the measured number lies above the stated range.
By their numbers in this assay, from the lowest: compound 1; then compound 2; then compound 3.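

In this assay, swapping one hydrogen for fluoro on this aromatic carbon gives a number 31 percentage points higher from compound 1 to compound 3 (beyond the scatter). The new fluoro stands ortho to a fluoro group, meta to a methyl group and para to a large group, and this position clearly responds to a change of a single heavy atom, so the change is far from a minor edit. Nothing measured here gives a reason for a step of this size.

The compounds shown leave open whether the gain belongs to fluoro itself or would also come with another group at this carbon, such as chloro, methoxy or an amine. They also leave open how the inhibition would change at other doses.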